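The source may hold more compounds than are shown below. What is called first, only, known or untested is meant among the compounds shown, and "the series" means these compounds.

Of the compounds shown here, three have so far been tested in an assay on isolated protein for inhibition of Amine oxidase [flavin-containing] B (Homo sapiens), read by fluorescence and Amplex Red, with stated times of 15 min and 20 min (on this read-out lower numbers stand for stronger inhibition and higher numbers for weaker inhibition), and all three share one core. Compound 1 `Oc1ccc(F)cc1/C=N/c1ccc(OCc2ccccc2)cc1` gives 15300 nM and stands second highest of the three numbers. Compound 3 `COc1ccc(/C=N/c2ccc(OCc3ccccc3)cc2)c(O)c1` gives 23600 nM, a number within the usual scatter of that for compound 1, so the two cannot be ranked against each other. Compound 2 `Oc1ccc(/C=N/c2ccc(OCc3ccccc3)cc2)c(O)c1O` gives 1730 nM, a clearly lower number that lies beyond the scatter. Compound 4 `Oc1ccc(Br)cc1/C=N/c1ccc(OCc2ccccc2)cc1` has not yet been measured; it differs from compound 1 by bromo in place of fluoro on an aromatic carbon. Within the data shown here, no measured pair shows this change, so the expectation rests on the change alone: a modest step toward a lower number, close to the edge of the scatter. Compound 4 is therefore expected to give 7000 nM, within a range from 2500 nM to 20000 nM. The estimated step is a 2.2-fold lower number from compound 1 to compound 4 (0.34 log units; beyond the scatter).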

Compound 4, half-maximal inhibitory concentration: 31700 nM
For compound 4 the middle estimate is 4.5-fold (0.66 log units) below the measured one; measured number outside the range, above it.
By their numbers in this assay, from the lowest: compound 2; then compounds 1, 3 and 4 (each within the scatter of the next, the first and the last beyond it).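

Bromo in place of fluoro, on the aromatic carbon para to the hydroxy group, gives a 2.1-fold higher number from compound 1 to compound 4 (0.32 log units; beyond the scatter) in the first direct comparison at this position. The step is modest, but it shows that the number at this position depends on which of these two halogens is present. No measurement shown here accounts for the step. Still open, as far as these compounds go, is whether chloro would give a number near those of these two halogens, and how an amine or a carboxylic acid at the same position would read.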